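The source may hold more compounds than are shown below. What is called first, only, known or untested is meant among the compounds shown, and "the series" means these compounds.

Measured compounds:
- compound 1 `O=C(O)c1csc([C@H]2CC[C@@H]3[C@@H](COc4ccc(C(F)(F)F)cc4)[C@H](O)C[C@@H]3O2)n1` — 13 nM
- compound 2 `O=C(O)c1csc([C@H]2CC[C@@H]3[C@@H](COc4ccc(F)cc4)[C@H](O)C[C@@H]3O2)n1` — 7 nM

Among the compounds with values here, in a functional assay on CHO cells for agonist activity at prostaglandin E2 receptor EP2 subtype (Homo sapiens), read by HTRF and cAMP accumulation, with a stated time of 30 min (on this read-out lower numbers stand for an effect already at smaller amounts and higher numbers for an effect only at larger amounts of compound), compound 2 gives the lowest of the two numbers, but its only neighbour is compound 1, and the single step of a 1.9-fold lower number from compound 1 to compound 2 (0.27 log units; within the scatter) does not separate the two. On these numbers compound 2 therefore stands level with compound 1 rather than ahead of it.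

Compound 3 `O=C(O)c1csc([C@H]2CC[C@@H]3[C@@H](CCCOc4ccccc4)[C@H](O)C[C@@H]3O2)n1` changes the side chain: 2-phenoxyethyl in place of 4-fluorophenoxy on a saturated chain carbon bound to a saturated ring carbon. Within the data shown here, no measured pair varies this part of the molecule in the same way. Among the measured compounds shown here, the one step available, from compound 1 to compound 2, swaps a substituent on the aromatic ring while leaving the link to the shared core untouched, so it bears only indirectly on the new compound. It does show that the aromatic substituent can be changed without moving the number beyond the scatter. For the measured compounds named here, the lengthening of the link and the loss of the fluorine have no precedent here, so a modest rise in the number, with wide uncertainty, is expected. The estimated step is a 3.6-fold higher number from compound 2 to compound 3 (0.55 log units; beyond the scatter). Compound 3 is expected to give 25 nM, within a range of 6 nM to 100 nM.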

Compound 3, half-maximal effective concentration: 10 nM
Compound 3: the middle estimate sits 2.5-fold (0.40 log units) above what was measured; measured number inside the range.
By their numbers in this assay, from the lowest: compounds 2, 3 and 1 (each within the scatter of the next).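

In this assay, the place on a saturated chain carbon bound to a saturated ring carbon accepts 2-phenoxyethyl in place of 4-fluorophenoxy, with a 1.4-fold higher number from compound 2 to compound 3 (0.15 log units; within the scatter) as the step, so the side chain itself can be changed without the number leaving the scatter. Earlier, only a substituent on the aromatic ring had been varied, with a 1.9-fold lower number from compound 1 to compound 2 (0.27 log units; within the scatter) as the step; the present step extends that result to the part joining the aromatic ring to the shared core, though it swaps the link and removes the fluorine in a single move, so the two changes cannot be read apart. No measurement in hand offers an explanation for this flat result.

The compounds shown leave open whether a longer chain than 2-phenoxyethyl, or an amine in place of the oxygen in that chain, would keep the number within the scatter of compound 3. Also open, as far as these compounds go, is how a fluoro group on the aromatic ring of 2-phenoxyethyl would read, which would separate the effect of the link from that of the fluorine.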